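The compounds below may be only part of what the source reports. "The series", "measured", "known", "first", "only" and "open" are said of these compounds alone.

For the measured compounds named here, compound 2 `Cc1noc(C)c1-c1cnc(N)c(Oc2ccc(C(=O)Nc3ccccc3)cc2)n1` is one of two compounds measured in a functional assay on HepG2 cells (Homo sapiens) for inhibition, read by MTT assay, with a stated time of 72 h; a lower number here means a stronger inhibitor, a higher number a weaker inhibitor; there compound 2 gives 11800 nM. The other, compound 1 `Cc1noc(C)c1-c1cnc(N)c(Oc2ccc(C(=O)NC3CC3)cc2)n1`, gives 43200 nM in this assay. Between them lies a single step, a 3.7-fold lower number from compound 1 to compound 2 (0.56 log units; beyond the scatter), which leaves compound 2 with the lower of the two numbers. Compound 3 `Cc1noc(C)c1-c1cnc(N)c(Oc2ccc(C(=O)Nc3ccc(Cl)cn3)cc2)n1` has not yet been measured. It differs from compound 2 in one place: 5-chloropyridin-2-yl in place of phenyl on an amide-type nitrogen. Going by the values given here, no measured step exchanges one aromatic ring for another on this amide-type nitrogen; the only step recorded, a 3.7-fold lower number from compound 1 to compound 2 (0.56 log units; beyond the scatter), sets a cyclopropyl against a phenyl and bears on compound 3 only in that an aromatic ring on the amide-type nitrogen is kept. The data therefore give no ground to expect a move beyond the scatter in this assay, and the step estimated here is a 1.3-fold lower number from compound 2 to compound 3 (0.12 log units; within the scatter). Compound 3 is accordingly expected to give about 9000 nM in this assay, with a range from 3000 nM to 30000 nM.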

Compound 3, half-maximal inhibitory concentration: 35600 nM
Compound 3: the middle estimate sits 4.0-fold (0.60 log units) below what was measured; measured number outside the range, above it.
By their numbers in this assay, from the lowest: compound 2; then compounds 3 and 1 (each within the scatter of the next).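

On the amide-type nitrogen, the earlier pair had only set a cyclopropyl against a phenyl; the new result shows that exchanging one aromatic ring for another here also moves the number in this assay, with a 3.0-fold higher number from compound 2 to compound 3 (0.48 log units; beyond the scatter) when 5-chloropyridin-2-yl enters in place of phenyl. An aromatic ring on this nitrogen is therefore not enough in itself to keep the phenyl's advantage, since a 1.2-fold lower number from compound 1 to compound 3 (0.08 log units; within the scatter) and places the 5-chloropyridin-2-yl compound level with the cyclopropyl compound, while compound 2 holds the lowest number of the three, with its steps to both others beyond the scatter. Nothing measured here accounts for this difference.

The change brings in a ring nitrogen and a chlorine together, so the three compounds cannot show what each contributes, and a pyridin-2-yl ring without the chlorine or a chlorophenyl ring without the ring nitrogen would be needed to separate the two. They also leave open how a morpholine or a longer alkyl chain would read on this same nitrogen.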